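The compounds below may be only part of what the source reports. "The series", "measured", "known", "first", "only" and "open" are said of these compounds alone.

Compound 1 `COc1ccc(-c2ccc3ncnc(NCCN(C)C)c3c2)cn1` gives 15900 nM in a functional assay on HCT-116 cells (Homo sapiens) for antiproliferative activity, read by MTT assay, with a stated time of 72 h (a higher number here means a weaker inhibitor, a lower number a stronger inhibitor), the highest of the three numbers recorded, so it is the weakest of the three measured compounds. Compound 2 `COc1ncc(-c2ccc3ncnc(NCCN(C)C)c3c2)cc1C#N` gives 560 nM in this assay, and compound 3 `CCN(CC)CCNc1ncnc2ccc(-c3cnc(OC)c([N+](=O)[O-])c3)cc12` gives 7330 nM. Compound 1 sits nearest to compound 3 and furthest from compound 2, the latter reached through a 28-fold lower number from compound 1 to compound 2 (1.45 log units; beyond the scatter), a change of cyano in place of hydrogen on an aromatic carbon.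

Compound 4 `COc1ccc(-c2ccc3ncnc(NCCN4CCCC4)c3c2)cn1` differs from compound 1 by pyrrolidin-1-yl in place of dimethylamino on a saturated chain carbon, two bonds along the chain from a nitrogen on an aromatic ring. Going by the values given here, no measured step bears on this change: the one recorded step, from compound 1 to compound 2, concerns a different change, and compound 3 differs from compound 1 in more than one place, so its value cannot be attributed to the amine alone. With nothing to anchor a direction, compound 4 is expected to give a step of a 1.2-fold lower number from compound 1 to compound 4 (0.09 log units; within the scatter), essentially no move beyond the scatter. Compound 4 is therefore estimated at 13000 nM, with a range from 5000 nM to 35000 nM.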

Compound 4, half-maximal inhibitory concentration: 3910 nM
Beside the measured number, compound 4's estimate is 3.3-fold (0.52 log units) above it, and the stated range ends above it.
By their numbers in this assay, from the lowest: compound 2; then compounds 4 and 3 (each within the scatter of the next); then compound 1.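

The amine at the end of the side chain proves to be a position that matters in this assay: pyrrolidin-1-yl in place of dimethylamino gives a 4.1-fold lower number from compound 1 to compound 4 (0.61 log units; beyond the scatter). The earlier compounds shown here showed a change only on the aromatic ring carrying the methoxy group, and this step, though beyond the scatter, is smaller than a 28-fold lower number from compound 1 to compound 2 (1.45 log units; beyond the scatter). No supporting evidence is available to explain why this change lowers the number.

Going by these compounds, it remains open whether the cyano and pyrrolidin-1-yl changes would add up when combined in one compound. The compounds shown also leave open how a piperidine or morpholine ring at the end of the chain, or a longer chain between the two nitrogens, would compare with pyrrolidin-1-yl.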